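A few compounds are considered here, and "the series" means these few. Any claim that something is new, unique, unknown or untested is made for them only; others in the source may bear on it.

Three related structures are at issue: compound 1 (`O=C(CC(CC(=O)NC1Cc2ccccc2C1)c1ccc(Cl)cc1)NCCN1CCCC1`), compound 2 (`CN(C(=O)CC(CC(=O)NCCN1CCCC1)c1ccccc1)C1Cc2ccccc2C1`) and compound 3 (`CN(C(=O)CC(CC(=O)NCCN1CCCC1)c1ccc(Cl)cc1)C1Cc2ccccc2C1`). In a functional assay on MCF7 cells (Homo sapiens) for inhibition (a lower number here means a stronger inhibitor, a higher number a weaker inhibitor), compound 1 gives > 100000 nM as a limit of the assay and not a number. Compound 2 gives > 100000 nM as a limit of the assay too, so it stands without a number of its own. Both measured compounds therefore rest at the same place (the limit of > 100000 nM in this assay, at which 2 of the 2 values shown sit). Compound 3 replaces the phenyl of compound 2 with 4-chlorophenyl (chloro in place of hydrogen on an aromatic carbon), chloro in place of hydrogen on an aromatic carbon. No measured step sizes this change. Compound 1 already carries 4-chlorophenyl and is held at the limit > 100000 nM in this assay, so no shift beyond the scatter is expected. The step of a number no higher from compound 2 to compound 3 (the limit leaves the size open) is estimated to be small. Compound 3 is expected near 100000 nM within an estimated range of 30000 nM to 200000 nM and is expected to sit at a limit of the assay again.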

Compound 3, half-maximal inhibitory concentration: 76700 nM
Estimate against measurement, compound 3: 1.3-fold (0.12 log units) above; low and high end bracket the measured number.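

Compound 3 is the only one of the three with a number of its own in this assay, so the change on the aromatic ring and the change on the amide nitrogen can now each be read, if only from one side. Chloro in place of hydrogen, para to a large group, gives an at least 1.3-fold lower number from compound 2 to compound 3 (0.11 log units; that floor lies within the scatter), and methyl on the amide-type nitrogen gives an at least 1.3-fold lower number from compound 1 to compound 3 (0.11 log units; that floor lies within the scatter). Neither step has a true size, because each starts from a compound held at a limit: the limit of > 100000 nM in this assay, at which 2 of the 3 values shown sit.

On these data alone, how large the two steps really are stays open. So does whether bromo or methoxy in place of the chloro, or ethyl in place of the methyl on the amide nitrogen, would give a clearly lower number.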